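Compound 3 to compound 4: chloro exchanged for bromo

A few compounds are considered here, and "the series" means these few. Any claim that something is new, unique, unknown or untested is made for them only; others in the source may bear on it.

Values in a functional assay on MDA-MB-231 cells (Homo sapiens) for antiproliferative activity, read by MTT assay, with a stated time of 72 h (a higher number here means a weaker inhibitor, a lower number a stronger inhibitor), are as follows

Compound 1 `NC1=NC2(CCSCC2)N(OCCCOc2ccc(Cl)c(Cl)c2)C(N)=N1` gives 10 nM
Compound 2 `NC1=NC2(CCSCC2)N(OCCCOc2ccc(Br)cc2)C(N)=N1` gives 440 nM
Compound 3 `NC1=NC2(CCOCC2)N(OCCCOc2ccccc2Cl)C(N)=N1` gives 1430 nM

In this assay compound 3 has the highest number of the three, with compound 2 nearest and compound 1 furthest. Compound 4 `NC1=NC2(CCOCC2)N(OCCCOc2ccccc2Br)C(N)=N1` has bromo in place of chloro on an aromatic carbon and is otherwise unchanged. Within the data shown here, the only measured step of a 44-fold higher number from compound 1 to compound 2 (1.64 log units; beyond the scatter) is large, but it exchanges 3,4-dichlorophenyl for 4-bromophenyl and so does not isolate this exchange. It sets neither size nor direction here, and no shift beyond the scatter is expected. The expected step is a 1.3-fold lower number from compound 3 to compound 4 (0.11 log units; within the scatter) and it leans slightly downward. Estimated for compound 4 is 1100 nM within an expected range from 400 nM to 3000 nM.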

Compound 4, half-maximal inhibitory concentration: 910 nM
For compound 4 the middle estimate is 1.2-fold (0.08 log units) above the measured one, within the range that was stated.
By their numbers in this assay, from the lowest: compound 1; then compound 2; then compounds 4 and 3 (each within the scatter of the next).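

In this assay, among these compounds, the exchange of chloro for bromo on an aromatic carbon, ortho to a large group, reads as a 1.6-fold lower number from compound 3 to compound 4 (0.20 log units; within the scatter) and is the first step that isolates one halogen. The two halogens are not told apart at this place, which the earlier step of a 44-fold higher number from compound 1 to compound 2 (1.64 log units; beyond the scatter) could not show, since it exchanges 3,4-dichlorophenyl for 4-bromophenyl. No measured evidence bears on this result.

Going by these compounds, whether an amine or a carboxylic acid at this place would read differently remains open. Also open, on these data alone, is whether the same exchange reads alike on the core of compound 1.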